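One Methoxy Group Fewer: Cytotoxicity in HOP-62 Cells

The source may hold more compounds than are shown below. What is called first, only, known or untested is meant among the compounds shown, and "the series" means these compounds.

The measured compounds:
compound 1, `COc1ccc(-c2cc(/C=C/C(=O)c3ccc(N)cc3)[nH]n2)cc1`: -60%
compound 2, `COc1ccc(-c2cc(/C=C/C(=O)c3ccc(N)cc3)[nH]n2)cc1OC`: -98%
compound 3, `COc1cc(C(=O)/C=C/c2cc(-c3cc(OC)c(OC)c(OC)c3)n[nH]2)cc(OC)c1OC`: -100%

All three were tested in a functional assay on HOP-62 cells (Homo sapiens) for cytotoxicity, read by sulforhodamine B assay, with a stated time of 48 h, tested at 100 uM; on this read-out higher numbers stand for a weaker effect at the one concentration tested and lower numbers for a stronger effect. Compound 2 and compound 1 share a core and differ in one place only: hydrogen in place of methoxy on an aromatic carbon. In this assay that change produced a number 38 percentage points higher from compound 2 to compound 1 (beyond the scatter), so the compound lacking the methoxy group came out weaker. The difference between the core of compound 3 and the core of compound 2 is not broken down here; their two values lie within the scatter of each other, so no order can be given between them.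

Compound 4, `COc1ccc(-c2cc(/C=C/C(=O)c3cc(OC)c(OC)c(OC)c3)[nH]n2)cc1OC`, has not yet been measured. It differs from compound 3 by hydrogen in place of methoxy on an aromatic carbon. This is the same kind of change as between compound 2 and compound 1, but not the same: around the place in compound 3 the carbon is also meta to a methoxy group. A step of similar direction and size, a number 32 percentage points higher from compound 3 to compound 4 (beyond the scatter), is expected, because a number 38 percentage points higher from compound 2 to compound 1 (beyond the scatter) was large and beyond the scatter. Compound 4 is therefore estimated at -68%, with a range from -100% to -30%.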

Compound 4, a percentage reported as activity, at one concentration (the size of the read-out at that concentration, not a potency): -84%
For compound 4 the middle estimate is 16 percentage points above the measured one; the measured number falls inside the stated range.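

In this assay, hydrogen in place of methoxy gave a number 16 percentage points higher from compound 3 to compound 4 (beyond the scatter), so the direction of the step seen on the core of compound 2 also held on the core of compound 3. The size of the step did not carry over from one core to the other: the same change on two cores in this assay, a number 38 percentage points higher (beyond the scatter) from compound 2 to compound 1 and a number 16 percentage points higher (beyond the scatter) from compound 3 to compound 4, 22 percentage points apart, beyond the scatter of two such steps. These two pairs therefore show that the direction held on both cores, but they do not show what sets the size of the step or how large it would be on a further core, and they do not explain why the two steps differ.

The compounds shown leave open whether another group at the same place, such as a hydroxyl group, a fluorine atom or an ethoxy group, would give a number closer to that of methoxy or to that of hydrogen. From the compounds shown here alone, it also remains open how the same change would behave on a core carrying a carboxylic acid or a longer chain in place of the amine of compound 1.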